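Reverting an amide substituent toward a ring-bearing amine

The source may hold more compounds than are shown below. What is called first, only, known or untested is meant among the compounds shown, and "the series" means these compounds.

The series shares one core carrying a sulfonamide-bearing aryl group and an amide, and differs only in the group on the amide nitrogen. Compound 1 `O=C(N[C@@H]1CCNC1)c1cc(-c2ccc(NS(=O)(=O)c3cccc(Cl)c3Cl)cc2)nc2[nH]ncc12` carries pyrrolidin-3-yl there. In an assay for inhibition of serine/threonine-protein kinase Sgk1 (Homo sapiens), with stated times of 30 min and 60 min, in the presence of a further agent that is not named here (a higher number here means a weaker inhibitor, a lower number a stronger inhibitor), compound 1 reaches only the assay limit of < 1 nM, a limit rather than a number. Compound 2 `CC(C)NC(=O)c1cc(-c2ccc(NS(=O)(=O)c3cccc(Cl)c3Cl)cc2)nc2[nH]ncc12` carries isopropyl instead, and in this assay compound 2 gives 17600 nM. The step of an at least 17000-fold higher number from compound 1 to compound 2 (4.24 log units; beyond the scatter) is therefore the only measured step, and compound 2 stands as the sole true number shown, with the other value being a limit (the limit of < 1 nM in this assay, at which 1 of the 2 values shown sits).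

Compound 3 `CN1CC(NC(=O)c2cc(-c3ccc(NS(=O)(=O)c4cccc(Cl)c4Cl)cc3)nc3[nH]ncc23)C1` is not yet measured. It differs from compound 2 by 1-methylazetidin-3-yl in place of isopropyl on an amide-type nitrogen. This change brings back a small nitrogen-containing ring on the amide nitrogen, as in compound 1, which sits at the limit < 1 nM. Given the size of an at least 17000-fold higher number from compound 1 to compound 2 (4.24 log units; beyond the scatter), compound 3 is expected to move strongly toward lower numbers in this assay, a step estimated as a 3500-fold lower number from compound 2 to compound 3 (3.55 log units; beyond the scatter). Compound 3 is thus estimated at 5 nM in this assay, within 0.5 nM to 100 nM.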

Compound 3, half-maximal inhibitory concentration: < 1 nM
Compound 3 was reported as a limit; the forecaster's own chance of this, stated with the estimate: 25%; middle value at least 5.0-fold (0.69 log units) from the limit.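

In this assay, putting 1-methylazetidin-3-yl in place of isopropyl on the amide-type nitrogen gives an at least 17000-fold lower number from compound 2 to compound 3 (4.24 log units; beyond the scatter), so the large gap seen earlier is not specific to pyrrolidin-3-yl. The change succeeds with a different nitrogen-containing ring, one that is four-membered and has a methyl group on its nitrogen, which shows that this position tolerates more than one such ring among the compounds shown. The reading for compound 3 is a limit rather than a number, and it is the same limit that compound 1 reached: the limit of < 1 nM in this assay, at which 2 of the 3 values shown sit.

With both readings being limits, the step between compound 1 and compound 3 cannot be read, and pyrrolidin-3-yl and 1-methylazetidin-3-yl cannot be ranked against each other in this assay. From the compounds shown here alone, it also remains open whether the ring or its nitrogen accounts for the difference from isopropyl: a cyclobutyl group, an oxetan-3-yl group or an open chain ending in a dimethylamino group on the same amide-type nitrogen would separate the two.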